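This account rests on a few compounds, and the source may have more. Where it says the series, first, only, none or still open, it means among the compounds named here.

Measured compounds:
compound 1, `COc1ccc2nc(SCC(=O)N(Cc3ccc(OC)c(O)c3)c3cc(OC)c(OC)c(OC)c3)sc2c1`, 4110 nM
compound 2, `COc1ccc(CN(C(=O)CSc2nc3ccccc3s2)c2cc(OC)c(OC)c(OC)c2)cc1N`, 7510 nM
compound 3, `COc1ccc(CN(C(=O)CSc2nc3ccccc3s2)c2cc(OC)c(OC)c(OC)c2)cc1C(F)(F)F`, > 80000 nM

Of the compounds shown here, three have been tested in a functional assay on PC-3 cells (Homo sapiens) for antiproliferative activity, read by MTT assay, with a stated time of 48 h; a lower number here means a stronger inhibitor, a higher number a weaker inhibitor. Compound 1 gives 4110 nM. Compound 2 differs from compound 1 in two places. Compound 2 gives 7510 nM, and the two numbers lie within the scatter of each other, so neither can be set apart from the other. For compound 3 the assay reports only a limit, > 80000 nM; this is the limit of > 80000 nM in this assay, at which 1 of the 3 values shown sits, and not a number. Among the measured compounds shown here, the one single-point step, an at least 10-fold higher number from compound 2 to compound 3 (1.02 log units; beyond the scatter), concerns the substituent on the benzyl ring and not the part that changes here.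

Compound 4, `COc1ccc(CN(C(=O)CSc2nc3c(C)cccc3s2)c2cc(OC)c(OC)c(OC)c2)cc1O`, is not yet measured in this assay. The change from compound 1 is 4-methyl-1,3-benzothiazol-2-yl in place of 6-methoxy-1,3-benzothiazol-2-yl on a sulfur. No measured step touches the 1,3-benzothiazol-2-yl part, so none of the shown steps bears on this change. Compound 4 is therefore expected to lie close to compound 1, with a step of a 1.2-fold higher number from compound 1 to compound 4 (0.09 log units; within the scatter) that is not expected to exceed the scatter. The estimate for compound 4 is 5000 nM, within a range from 1500 nM to 20000 nM.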

Compound 4, half-maximal inhibitory concentration: 12300 nM
Compound 4: the middle estimate sits 2.5-fold (0.39 log units) below what was measured; low and high end bracket the measured number.
By their numbers in this assay, from the lowest: compounds 1, 2 and 4 (each within the scatter of the next, the first and the last beyond it). At a limit, above all of these: compound 3.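

In this assay, the 1,3-benzothiazol-2-yl part on the sulfur proves not to be indifferent: with the rest of the molecule unchanged, the exchange gives a 3.0-fold higher number from compound 1 to compound 4 (0.48 log units; beyond the scatter). This step is modest, but it is the only one shown for this part of the series, and it runs towards weaker inhibition. The exchange removes the 6-methoxy group and brings in the 4-methyl group together, so the step cannot be assigned to either alone, and nothing shown accounts for it.

From the compounds shown here alone, it remains open how a chlorine, an amine or a carboxylic acid on the 1,3-benzothiazol-2-yl part would compare with these two groups. Going by these compounds, it is also open whether the same exchange would give a similar step with the amino-bearing benzyl group of compound 2.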